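The source may report more compounds than this note shows. Statements on the series, on what has been measured and on what is new or still open speak of the compounds shown alone.

Measured compounds in the series:

- compound 1, `CN(C)CCn1cnnc1-c1cc(Oc2ccc(NC(=O)N/N=C/c3ccccc3O[N+](=O)[O-])cc2F)ccn1`: 1200 nM
- compound 2, `CN(C)CCn1cnnc1-c1cc(Oc2ccc(NC(=O)N/N=C/c3cc(Br)c(O)c(Br)c3)cc2F)ccn1`: > 100000 nM

In a functional assay on A549 cells (Homo sapiens) for cytotoxicity, read by MTT assay, with a stated time of 72 h (on this read-out higher numbers stand for weaker inhibition and lower numbers for stronger inhibition), compound 1 gives 1200 nM. For compound 2 this assay reports only a limit, > 100000 nM; this is the limit of > 100000 nM in this assay, at which 1 of the 2 values shown sits, so compound 2 stands at the weak end of the numbers shown, with no exact value. For the measured compounds named here, the single measured step, an at least 83-fold higher number from compound 1 to compound 2 (1.92 log units; beyond the scatter), is therefore itself an at-least figure.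

Compound 3, `COc1cc(/C=N/NC(=O)Nc2ccc(Oc3ccnc(-c4nncn4CCN(C)C)c3)c(F)c2)ccc1O`, differs from compound 2 in one place: 4-hydroxy-3-methoxyphenyl in place of 3,5-dibromo-4-hydroxyphenyl on a carbon with a double bond to nitrogen. Going by the values given here, no measured step covers this exchange; the only step known, an at least 83-fold higher number from compound 1 to compound 2 (1.92 log units; beyond the scatter), concerns a different aryl group on the same carbon and shows that this position can move the read-out by a large amount. Since compound 2 is a limit, a step from compound 2 to compound 3 can only be downward or none, and its size cannot be set from the data. Compound 3 is expected to fall at 30000 nM, between 3000 nM and 100000 nM, which means an expected step of an at least 3.3-fold lower number from compound 2 to compound 3 (0.52 log units; beyond the scatter) in this assay, with a fair chance that compound 3 too is reported only as a limit.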

Compound 3, half-maximal inhibitory concentration: > 100000 nM
Compound 3 ended at the assay's limit (the forecaster's own chance of this, stated with the estimate: 40%); middle value at least 3.3-fold (0.52 log units) from the limit.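

In this assay, the exchange of 2-(nitrooxy)phenyl for 4-hydroxy-3-methoxyphenyl gives an at least 83-fold higher number from compound 1 to compound 3 (1.92 log units; beyond the scatter), so a large rise in the number at this carbon with a double bond to nitrogen is no longer tied to 3,5-dibromo-4-hydroxyphenyl alone. Among the three compounds, only compound 1, with 2-(nitrooxy)phenyl, gives an exact value, while both aryl groups carrying a hydroxyl and a further substituent leave the read-out at the end of the range, with or without bromine. Compound 3 is reported only as a limit, as is compound 2, and the step between them cannot be read: the limit of > 100000 nM in this assay, at which 2 of the 3 values shown sit.

On these data alone, it remains open which part of 2-(nitrooxy)phenyl goes with the measurable value of compound 1, and whether the hydroxyl shared by compound 2 and compound 3 has any bearing on their readings. Plain phenyl, a nitrophenyl or an aminophenyl on the same carbon would help to separate these possibilities, and any difference between compound 2 and compound 3 remains hidden behind their limits.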